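From benzyl to 4-fluorobenzyl on the compound 2 scaffold

The source may hold more compounds than are shown below. What is called first, only, known or untested is meant among the compounds shown, and "the series" means these compounds.

In a functional assay on HL-60 cells (Homo sapiens) for inhibition, read by CCK-8 assay, with a stated time of 48 h, tested at 20 uM (a higher number here means more inhibition of growth at the concentration tested, a lower number less inhibition of growth), compound 1 `COc1ccc(S(=O)(=O)Oc2ccccc2/C=C(\C#N)C(=O)Nc2nnc(-c3cccs3)s2)cc1` gives 67%, while compound 2 `COc1ccc(S(=O)(=O)Oc2ccccc2/C=C(\C#N)C(=O)Nc2nnc(Cc3ccccc3)s2)cc1` gives 100%, the higher of the two numbers. Going by the values given here, the single measured step is a number 33 percentage points higher from compound 1 to compound 2 (beyond the scatter). It is large, and it comes from benzyl in place of thiophen-2-yl on an aromatic carbon.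

Compound 3 `COc1ccc(S(=O)(=O)Oc2ccccc2/C=C(\C#N)C(=O)Nc2nnc(Cc3ccc(F)cc3)s2)cc1` differs from compound 2 by one change: fluoro in place of hydrogen on an aromatic carbon. This is fluoro in place of hydrogen on an aromatic carbon, para to a large group, so benzyl becomes 4-fluorobenzyl.

Among the compounds with values here, no measured step covers this kind of change. The step of a number 33 percentage points higher from compound 1 to compound 2 (beyond the scatter) bears on it only loosely: it shows that the group at this place can matter, but it swaps a whole group rather than a single atom. Compound 2 at 100% leaves no room for a rise on this read-out, so any real movement can only be downward, and no step beyond the scatter is the likeliest outcome. The expected step is a number 7 percentage points lower from compound 2 to compound 3 (within the scatter). For compound 3 the estimated value is 93%, with an expected range of 72% to 100%.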

Compound 3, percent growth inhibition at one concentration: 100%
Estimate against measurement, compound 3: 7 percentage points below; low and high end bracket the measured number.
By their numbers in this assay, from the lowest: compound 1; then compounds 2 and 3 (each within the scatter of the next).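

Read in this assay, fluoro in place of hydrogen on an aromatic carbon, para to a large group, gives no change at the digits printed from compound 2 to compound 3 (within the scatter) and so leaves the benzyl result intact on this read-out. The advantage over thiophen-2-yl carries over to the substituted group, with a number 33 percentage points higher from compound 1 to compound 3 (beyond the scatter) and thus a step of the same large size as the one seen with benzyl, so that step is not confined to the unsubstituted benzyl group. Nothing available gives a reason for either step.

Compound 2 and compound 3 both stand at the top of this single-concentration read-out, so any difference between them that lies beyond that top is hidden, and a lower test concentration or a full dose-response measurement would be needed to separate them. Also open, going by these compounds, is whether the number holds with other groups at this place, such as 4-methoxybenzyl, 4-aminobenzyl, 4-carboxybenzyl or the longer phenethyl chain.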